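Pyrimidinyl for Pyrazinyl on the Imidazoline Aryl Ether Core

The source may report more compounds than this note shows. Statements on the series, on what has been measured and on what is new or still open speak of the compounds shown alone.

Compound 1 `c1cncc(-c2ccccc2OCC2=NCCN2)c1`: 79.4 nM
Compound 2 `c1ccc(-c2cnccn2)c(OCC2=NCCN2)c1`: 631 nM

In a functional assay for activation of Alpha-1B adrenergic receptor (Homo sapiens), read by calcium flux (a higher number here means that more compound is needed for the effect, a lower number that less compound is needed), compound 2 gives the highest number of the two measured compounds, with compound 1 nearest at a 7.9-fold higher number from compound 1 to compound 2 (0.90 log units; beyond the scatter). Compound 3 `c1ccc(-c2ccncn2)c(OCC2=NCCN2)c1` differs from compound 2 by pyrimidin-4-yl in place of pyrazin-2-yl on an aromatic carbon, a change at the same aromatic carbon where the step from compound 1 to compound 2 occurred. For the measured compounds named here, that step, a 7.9-fold higher number from compound 1 to compound 2 (0.90 log units; beyond the scatter), is the only one bearing on this change, and it exchanged one azine for another diazine; no measured pair exchanges two diazines. The step for compound 3 is therefore expected to be a 1.3-fold lower number from compound 2 to compound 3 (0.10 log units; within the scatter), likely within the scatter. Compound 3 is estimated at 500 nM, between 150 nM and 1600 nM.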

Compound 3, half-maximal effective concentration: < 100000 nM
Compound 3 ended at the assay's limit; the forecaster's own chance of this, stated with the estimate: 5%; the middle value does not contradict the limit.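

In this assay compound 3 gives < 100000 nM, which is a limit of the assay and not a number, so its steps from compound 1 and compound 2 cannot be read. The compounds shown leave open how pyrimidin-4-yl compares with pyrazin-2-yl and pyridin-3-yl at this aromatic carbon.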